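A few compounds are considered here, and "the series" means these few. Any claim that something is new, unique, unknown or untested is made for them only; others in the source may bear on it.

Compound 1 `COc1ccc(OC)c(N2C(=O)CSC2c2cccc(C(=O)NCCCCc3ccccc3)c2)c1`: > 1000 nM
Compound 2 `COc1cccc(OC)c1N1C(=O)CSC1c1cccc(C(=O)NCCCCc2ccccc2)c1`: > 1000 nM
Compound 3 `COc1c(F)cccc1N1C(=O)CSC1c1cccc(C(=O)NCCCCc2ccccc2)c1`: 26.2 nM

All three were tested in a functional assay on HOS-TE85 cells (Homo sapiens) for inhibition, read by CCK-8 assay, with a stated time of 72 h; on this read-out higher numbers stand for weaker inhibition and lower numbers for stronger inhibition. For compound 1 the value is a limit of this assay, not a number. For compound 2 the value is likewise a limit. Compound 3 gives the only number shown and is therefore the firmest point here. The shift an at least 38-fold lower number from compound 1 to compound 3 (1.58 log units; beyond the scatter) and the shift an at least 38-fold lower number from compound 2 to compound 3 (1.58 log units; beyond the scatter) both concern the group on the amide-type nitrogen in a ring, while a step that the two limits leave unreadable from compound 1 to compound 2 stays unreadable. Compound 4 `O=C(NCCCCc1ccccc1)c1cccc(C2SCC(=O)N2c2cnccn2)c1` alters the same place: pyrazin-2-yl in place of 3-fluoro-2-methoxyphenyl on an amide-type nitrogen in a ring. Because two of the three groups tried there sit at the limit of > 1000 nM in this assay, at which 2 of the 3 values shown sit, a step toward weaker inhibition, expected as an 11-fold higher number from compound 3 to compound 4 (1.06 log units; beyond the scatter), seems likelier than a gain. Compound 4 is estimated at 300 nM, between 60 nM and 1500 nM.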

Compound 4, half-maximal inhibitory concentration: > 1000 nM
Compound 4 was reported as a limit; the forecaster's own chance of this, stated with the estimate: 35%; middle value at least 3.3-fold (0.52 log units) from the limit.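

Pyrazin-2-yl, a six-membered aromatic ring with 2 hetero atoms, does not keep the activity of the carbon-only 3-fluoro-2-methoxyphenyl, giving an at least 38-fold higher number from compound 3 to compound 4 (1.58 log units; beyond the scatter). Compound 4 gives > 1000 nM, which is a limit, and its steps from compound 1 and compound 2 cannot be read. Among the groups on this nitrogen, only 3-fluoro-2-methoxyphenyl gives a number so far: the limit of > 1000 nM in this assay, at which 3 of the 4 values shown sit.

From the compounds shown here alone, this change swaps the ring atoms and removes the fluorine and the methoxy together, so it remains open which of these matters. Plain phenyl, 2-methoxyphenyl or 3-fluorophenyl on the same nitrogen would help separate them.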